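Swapping one end group on compound 2

The compounds below may be only part of what the source reports. "The series", "measured", "known", "first", "only" and "open" are said of these compounds alone.

In an ADME assay on the whole organism (Mus musculus, strain BALB/c) for pharmacokinetics, read by LC-MS, at a dose of 3 mg/kg by the intravenous route (a lower number here means slower removal, a higher number faster removal of the compound), compound 1 (`CCn1nc(C)cc1C(=O)NCCCCn1c(NC(=O)c2cc(C)nn2CC)nc2cc(C(N)=O)ccc21`) comes in at 158 mL/min/kg as its measured clearance. Compound 2 (`CCn1nc(C)cc1C(=O)Nc1nc2cc(C(N)=O)cc(OC)c2n1C/C=C/Cn1c(NC(=O)c2cc(C)nn2CC)nc2cc(C(N)=O)cc(OCCCNC(=O)OC(C)(C)C)c21`) stands at 35.3 mL/min/kg and holds the lower of the two numbers, a gap beyond the usual scatter. Compound 1 and compound 2 differ in more than one place, so that gap cannot be tied to any single change. Compound 3 (`CCn1nc(C)cc1C(=O)NCCCOc1cc(C(N)=O)cc2nc(NC(=O)c3cc(C)nn3CC)n(C/C=C/Cn3c(NC(=O)c4cc(C)nn4CC)nc4cc(C(N)=O)cc(OC)c43)c12`) is built from compound 2 with one change. The change 1-ethyl-3-methyl-1H-pyrazol-5-yl in place of tert-butoxy on a carbonyl carbon puts 1-ethyl-3-methyl-1H-pyrazol-5-yl in place of tert-butoxy on a carbonyl carbon. Among the compounds with values here, no measured pair shows what such a swap does, so the data offer no direction. In this assay no shift beyond the scatter is expected, and the estimated step of a 1.1-fold lower number from compound 2 to compound 3 (0.04 log units; within the scatter) stays small. For compound 3 the estimated clearance is 32 mL/min/kg with an expected range from 15 mL/min/kg to 70 mL/min/kg in this measurement.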

Compound 3, clearance: 12 mL/min/kg
Compound 3: the middle estimate sits 2.7-fold (0.43 log units) above what was measured; the whole stated range lies above it.
By their numbers in this assay, from the lowest: compound 3; then compound 2; then compound 1.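

In this assay putting 1-ethyl-3-methyl-1H-pyrazol-5-yl in place of tert-butoxy on a carbonyl carbon gives a 2.9-fold lower number from compound 2 to compound 3 (0.47 log units; beyond the scatter) as a modest step. Within the data shown here, this is the first measured single change in the set, and it shows that the group on this carbonyl carbon can shift clearance, here towards slower removal. No measurement explains the shift or separates the loss of tert-butoxy from the arrival of the pyrazole ring.

The compounds shown leave open whether the lower number needs this particular ring or would also come with a plain phenyl ring or a simple methyl group on the same carbonyl carbon. They also leave open what an amine or a carboxylic acid at this end of the chain would do.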